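Swapping the aromatic ring on an acid ceramidase inhibitor

This account rests on a few compounds, and the source may have more. Where it says the series, first, only, none or still open, it means among the compounds named here.

Compound 1 `O=C(NCCCCc1ccccc1)n1cc(-c2ccccn2)oc1=O` and compound 2 `O=C(NCCCCc1ccccc1)n1cc(-c2cnccn2)oc1=O` share one core and differ only in the ring attached to it. In an assay on isolated protein for inhibition of acid ceramidase (Homo sapiens), read by LC-MS, with a stated time of 1 h (a higher number here means a weaker inhibitor, a lower number a stronger inhibitor), compound 1 gives 25 nM, and compound 2 gives 32 nM; the step of a 1.3-fold higher number from compound 1 to compound 2 (0.11 log units; within the scatter) is within the scatter, so compound 2 stands level with compound 1 on the two numbers shown. Compound 3 `O=C(NCCCCc1ccccc1)n1cc(-c2cscn2)oc1=O` carries 1,3-thiazol-4-yl in place of pyrazin-2-yl on an aromatic carbon. For the measured compounds named here, the only step that bears on this change is a 1.3-fold higher number from compound 1 to compound 2 (0.11 log units; within the scatter), a ring swap at the same place that barely moved the number, so no step beyond the scatter is expected. Compound 3 is estimated at 32 nM, between 10 nM and 100 nM, an expected step of no change at the digits printed from compound 2 to compound 3 (within the scatter).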

Compound 3, half-maximal inhibitory concentration: 44 nM
Compound 3: middle estimate off by 1.4-fold (0.14 log units), on the low side, and the stated range covers the measured number.
By their numbers in this assay, from the lowest: compounds 1, 2 and 3 (each within the scatter of the next).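

This position is not limited to six-membered aromatic rings. The five-membered 1,3-thiazol-4-yl, which brings a sulfur atom into the ring, gives no step beyond the scatter in this assay against either six-membered ring (first a 1.4-fold higher number from compound 2 to compound 3 (0.14 log units; within the scatter) and then a 1.8-fold higher number from compound 1 to compound 3 (0.25 log units; within the scatter)). All three aromatic rings therefore read alike here.

As far as these compounds go, it stays open whether a non-aromatic ring such as cyclohexyl, or an aromatic ring carrying an amine or a carboxylic acid, would also keep the number in this range. No measurement offered here gives a reason for this sameness.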